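The compounds below may be only part of what the source reports. "The series", "measured", "known", "first", "only" and "open" are said of these compounds alone.

Working notes on the series. In a functional assay on HeLa cells (Homo sapiens) for inhibition, read by CCK-8 assay, with a stated time of 72 h, tested at 8 uM (a higher number here means more inhibition of growth at the concentration tested, a lower number less inhibition of growth), compound 1 (`COc1ccc(SCc2ccc(/C=C/C(=O)Nc3ccccc3N)cc2)cc1OC`) gives 21.9% and compound 2 (`Nc1ccccc1NC(=O)/C=C/c1ccc(CSc2cccc(F)c2)cc1`) gives 18.6% for growth inhibition. Compound 3 (`Nc1ccccc1NC(=O)c1ccc(CSc2cccc(F)c2)cc1`) gives 78.4% in the same read-out, the highest of the three numbers and beyond the scatter from both of the others.

Compound 4 (`Cc1cc(C)cc(SCc2ccc(C(=O)Nc3ccccc3N)cc2)c1`) is the next to read. Its difference from compound 3 is 3,5-dimethylphenyl in place of 3-fluorophenyl on a sulfur and the shared core stays as it is. In words, 3,5-dimethylphenyl replaces 3-fluorophenyl on a sulfur.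

Among the compounds with values here, only one measured step concerns a swap at this place, a number 3.3 percentage points lower from compound 1 to compound 2 (within the scatter) and it stays within the scatter. Within the data shown here, that step comes from a different core with low numbers, and no measured step starts from compound 3, so its transfer is uncertain. No step beyond the scatter is therefore expected, though the range is kept wide. The estimate is a number 6.4 percentage points lower from compound 3 to compound 4 (within the scatter) in this assay as a modest expected drop. Compound 4 is expected at 72% (estimated range 50% to 90%) in this read-out.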

Compound 4, percent growth inhibition at one concentration: 78.9%
Compound 4: middle estimate off by 6.9 percentage points, on the low side, within the range that was stated.
By their numbers in this assay, from the lowest: compounds 2 and 1 (each within the scatter of the next); then compounds 3 and 4 (each within the scatter of the next).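

With 3,5-dimethylphenyl in place of 3-fluorophenyl on a sulfur, this assay gives a number 0.5 percentage points higher from compound 3 to compound 4 (within the scatter), so a swap at this place is now read on the core that carries the high numbers, and the high reading of compound 3 is kept. Together with the earlier step on the low-reading core, this gives two swaps at this place, and neither moves the number beyond the scatter; the fluorine can go and two methyl groups can enter without a visible change at this single concentration. No supporting data bear on why the two groups read alike.

Open, going by these compounds, is whether this tolerance extends to an amine or a carboxylic acid on that aromatic ring, or to a longer chain on the sulfur in place of the ring. A single-concentration read-out also leaves open whether compound 3 and compound 4 would still read alike at lower concentrations.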